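From methyl to trifluoromethyl at the assay limit

The compounds below may be only part of what the source reports. "The series", "measured", "known", "first", "only" and "open" are said of these compounds alone.

In an ADME assay on MDBK cells (Bos taurus) for cytotoxicity, read by MTT assay, with a stated time of 72 h (a higher number here means that more compound is tolerated, a lower number that less compound is tolerated), compound 3 (`Cc1ccc(-c2nn(-c3ccccc3)cc2CNc2ccc(Br)cc2)cc1`) gives > 100000 nM as a limit of the assay and not a number. Compound 2 (`Brc1ccc(NCc2cn(-c3ccccc3)nc2-c2ccccc2)cc1`) gives > 100000 nM and this too is only a limit. Compound 3 therefore stands at the limit of > 100000 nM in this assay, at which 2 of the 3 values shown sit, and offers no exact starting point. The change to compound 4 (`FC(F)(F)c1ccc(-c2nn(-c3ccccc3)cc2CNc2ccc(Br)cc2)cc1`) is trifluoromethyl in place of methyl on an aromatic carbon. Going by the values given here, the one measured step at this place, methyl in place of hydrogen on an aromatic carbon, is a step that the two limits leave unreadable from compound 2 to compound 3 and so offers no size to carry over. The better guide is compound 1 (`FC(F)(F)c1ccc(-c2nn(-c3ccccc3)cc2CNc2ccc(Cl)cc2)cc1`), which also holds the 4-(trifluoromethyl)phenyl group and gives 44000 nM as a true number in this assay here. On that basis, the expected change is an at least 2.0-fold lower number from compound 3 to compound 4 (0.30 log units; that floor lies within the scatter) in the direction of less compound tolerated. The estimate for compound 4 is 50000 nM with an expected range from 20000 nM to 100000 nM in this assay when measured.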

Compound 4, half-maximal cytotoxic concentration: 64000 nM
Compound 4: middle estimate off by 1.3-fold (0.11 log units), on the low side; measured number inside the range.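

In this assay, compound 4 is the first bromo compound shown to give a true number rather than a limit, so trifluoromethyl in place of methyl now reads as an at least 1.5-fold lower number from compound 3 to compound 4 (0.19 log units; that floor lies within the scatter), and trifluoromethyl in place of hydrogen as an at least 1.5-fold lower number from compound 2 to compound 4 (0.19 log units; that floor lies within the scatter). Both steps are only minimum sizes that lie within the scatter, and their true sizes stay hidden: the limit of > 100000 nM in this assay, at which 2 of the 4 values shown sit. Bromo in place of chloro reads as a 1.5-fold higher number from compound 1 to compound 4 (0.16 log units; within the scatter), which is also within the scatter, so with 4-(trifluoromethyl)phenyl in place this exchange shows no clear change.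

The step from hydrogen to methyl cannot be read, so the compounds shown do not order these two groups. As far as these compounds go, it also remains open how an amine or a carboxylic acid in place of trifluoromethyl at this position would read in this assay.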